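This account rests on a few compounds, and the source may have more. Where it says the series, first, only, none or still open, it means among the compounds named here.

Three analogues sharing one core have been measured in a functional assay on HCT-116 cells (Homo sapiens) for cytotoxicity, read by MTT assay, with a stated time of 48 h; on this read-out higher numbers stand for weaker inhibition and lower numbers for stronger inhibition. Compound 1 `O=C(CSCc1nc2cc([N+](=O)[O-])ccc2[nH]1)c1ccc(Cl)cc1` gives 2230 nM, compound 2 `NC(=O)CSCc1nc2cc([N+](=O)[O-])ccc2[nH]1` gives 17200 nM and compound 3 `NC(=S)NNC(=O)CSCc1nc2cc([N+](=O)[O-])ccc2[nH]1` gives 4710 nM. Compound 3 therefore stands second of the three: a 2.1-fold higher number from compound 1 to compound 3 (0.32 log units; beyond the scatter), while a 3.7-fold lower number from compound 2 to compound 3 (0.56 log units; beyond the scatter). The next step, to compound 4 `CC1=NN(C(=O)CSCc2nc3cc([N+](=O)[O-])ccc3[nH]2)C(=O)C1`, puts (a group of 7 heavy atoms (4 carbon, 2 nitrogen, 1 oxygen; one five-membered non-aromatic ring with 2 hetero atoms) in place of a group of 5 heavy atoms (1 carbon, 3 nitrogen, 1 sulfur; no ring), on a carbonyl carbon). The measured steps that bear on this are the two at the same carbonyl carbon: a 7.7-fold higher number from compound 1 to compound 2 (0.89 log units; beyond the scatter) and a 2.1-fold higher number from compound 1 to compound 3 (0.32 log units; beyond the scatter), both modest. The entering group resembles neither of the groups already tried there, so no step beyond the scatter in this assay is expected in either direction. Compound 4 is accordingly estimated at 3500 nM, with a range from 1000 nM to 12000 nM. The expected step is a 1.3-fold lower number from compound 3 to compound 4 (0.13 log units; within the scatter).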

Compound 4, half-maximal inhibitory concentration: 5410 nM
Estimate against measurement, compound 4: 1.5-fold (0.19 log units) below; low and high end bracket the measured number.
By their numbers in this assay, from the lowest: compound 1; then compounds 3 and 4 (each within the scatter of the next); then compound 2.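

In this assay, the five-membered non-aromatic ring with 2 hetero atoms on the carbonyl carbon reads level with the ringless group of compound 3 (a 1.1-fold higher number from compound 3 to compound 4 (0.06 log units; within the scatter)), although the entering group has 0 hydrogen-bond donors and the leaving group 3. The ring still gives a stronger result than the amino group (a 3.2-fold lower number from compound 2 to compound 4 (0.50 log units; beyond the scatter)) and a weaker one than 4-chlorophenyl (a 2.4-fold higher number from compound 1 to compound 4 (0.38 log units; beyond the scatter)). Nothing available here accounts for these steps.

Going by these compounds, it remains open whether a carboxylic acid or a morpholine ring on this carbonyl carbon would match 4-chlorophenyl. Changes to the shared core also remain open.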